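Difluorophenyl in Place of Methoxyphenyl: Cytotoxicity Outlook

This account rests on a few compounds, and the source may have more. Where it says the series, first, only, none or still open, it means among the compounds named here.

Compound 2 `COc1ccc(-c2nnsc2SCC(=O)Nc2ccccc2F)cc1` was examined in an ADME assay on MT4 cells (Homo sapiens) for cytotoxicity; on this read-out higher numbers stand for lower toxicity in this test and lower numbers for higher toxicity in this test. In this assay compound 2 gives > 332000 nM, which is a limit of the assay and not a number. Among the compounds with values here, its single measured neighbour is compound 1 `O=C(CSc1snnc1-c1ccccc1)Nc1ccccc1F`. In this assay compound 1 gives > 361000 nM, likewise a limit of the assay. The step between them, a step that the two limits leave unreadable from compound 1 to compound 2, cannot be read because the limit of > 332000 nM in this assay, at which 1 of the 2 values shown sits, and the limit of > 361000 nM in this assay, at which 1 of the 2 values shown sits, both sit at limits.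

Compound 3 `O=C(CSc1snnc1-c1ccc(F)cc1F)Nc1ccccc1F` differs from compound 2 by 2,4-difluorophenyl in place of 4-methoxyphenyl on an aromatic carbon. Within the data shown here, no measured step bears on this change, and the one step at hand, from compound 1 to compound 2, is unreadable. Compound 3 is therefore expected to stand where compound 2 stands, with an expected step of a number no higher from compound 2 to compound 3 (the limit leaves the size open) in this assay, none beyond the scatter. Compound 3 is estimated at 330000 nM, within 100000 nM to 600000 nM, probably once more as a limit.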

Compound 3, half-maximal cytotoxic concentration: 148000 nM
Estimate against measurement, compound 3: 2.2-fold (0.35 log units) above; measured number inside the range.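

Compound 3 is the only compound shown that gives a number rather than a limit, and this shows that the group on this aromatic carbon of the shared core can shift the reading in this assay. Here, 2,4-difluorophenyl in place of 4-methoxyphenyl gives an at least 2.2-fold lower number from compound 2 to compound 3 (0.35 log units; beyond the scatter), and the same group in place of phenyl gives an at least 2.4-fold lower number from compound 1 to compound 3 (0.38 log units; beyond the scatter). Both steps point towards higher toxicity in this test, and both are minimum sizes, as compound 1 and compound 2 each stand at a limit of the assay.

Going by these compounds, the two fluorine atoms of compound 3 enter together, so it remains open whether a 4-fluorophenyl group alone would give a similar step. On these data alone, how a 4-chlorophenyl or 4-aminophenyl group would read at this position also remains open.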